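Extending the Amine Chain in a Demethylase Inhibitor Series

The source may report more compounds than this note shows. Statements on the series, on what has been measured and on what is new or still open speak of the compounds shown alone.

Measured so far in an assay on isolated protein for inhibition of lysine-specific demethylase 5A (Homo sapiens), with a stated time of 60 min; a higher number here means a weaker inhibitor, a lower number a stronger inhibitor:
compound 1 `CCCCN(C)CCCCC(=O)N(O)CCC(=O)O` gives 4300 nM;
compound 2 `CCCN(C)CCCCC(=O)N(O)CCC(=O)O` gives 8900 nM;
compound 3 `CCCCCN(C)CCCCC(=O)N(O)CCC(=O)OC` gives 63000 nM.

Compound 1 differs from compound 2 by methyl in place of hydrogen on a saturated chain carbon, three bonds along the chain from an amine nitrogen, and this step is a 2.1-fold lower number from compound 2 to compound 1 (0.32 log units; beyond the scatter). Compound 3 carries a different core; the difference between the two cores is not broken down here. Compound 4 `CCCCCCN(C)CCCCC(=O)N(O)CCC(=O)OC` has not yet been tested; it differs from compound 3 by methyl in place of hydrogen on a saturated chain carbon, five bonds along the chain from an amine nitrogen. The place is not the same as before: the earlier methyl sat three bonds along the chain from an amine nitrogen, this one five bonds along, so it is the same kind of change, not the same. Resting on compound 1 and compound 2, a step of a 1.6-fold lower number from compound 3 to compound 4 (0.20 log units; within the scatter) is expected, so compound 4 is estimated at 40000 nM, likely between 15000 nM and 120000 nM.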

Compound 4, half-maximal inhibitory concentration: 21000 nM
Estimate against measurement, compound 4: 1.9-fold (0.28 log units) above, within the range that was stated.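

In this assay, methyl in place of hydrogen, five bonds along the chain from an amine nitrogen, gives a 3.0-fold lower number from compound 3 to compound 4 (0.48 log units; beyond the scatter). Set beside the earlier step, this kind of change lowers the number on both cores by amounts that cannot be told apart: the same change on two cores in this assay, a 2.1-fold lower number (0.32 log units; beyond the scatter) from compound 2 to compound 1 and a 3.0-fold lower number (0.48 log units; beyond the scatter) from compound 3 to compound 4, 1.4-fold (0.16 log units) apart, within the scatter of two such steps. Among these compounds, this rests on only two pairs, with the methyl at a different place along the chain in each, so it suggests that the change carries over between these two cores but does not show that it would carry to any other core or chain length.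

From the compounds shown here alone, whether a heptyl chain on the amine nitrogen would lower the number further remains open. So does how an ethyl ester would compare with the methyl ester of compound 4.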